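Chain length on the shared core and a limit

This account rests on a few compounds, and the source may have more. Where it says the series, first, only, none or still open, it means among the compounds named here.

Compound 1, `CCc1cn([C@H]2C[C@@H]3OP(=O)(O)OC[C@H]3O2)c(=O)[nH]c1=O`: in a functional assay on Raji cells (Homo sapiens) (on this read-out lower numbers stand for stronger inhibition and higher numbers for weaker inhibition), compound 1 gives > 500 ug/mL, a limit of the assay.
Compound 2, `CCCCc1cn([C@H]2C[C@H](O)[C@@H](CO)O2)c(=O)[nH]c1=O`: compound 2 gives > 500 ug/mL, also a limit.
Compound 3, `CC(C)c1cn([C@H]2C[C@@H]3OP(=O)(O)OC[C@H]3O2)c(=O)[nH]c1=O`: compound 3 gives > 500 ug/mL, again a limit.

All three measured values sit at the limit of > 500 ug/mL in this assay, at which 3 of the 3 values shown sit, so none of them is a number. The difference between the cores of compound 1 and compound 2 is not broken down here. Compound 3 differs from compound 1 by methyl in place of hydrogen on a saturated chain carbon bound to an aromatic carbon and a saturated chain carbon, and the step this makes is a step that the two limits leave unreadable from compound 1 to compound 3.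

Compound 4, `CCCCCc1cn([C@H]2C[C@H](O)[C@@H](CO)O2)c(=O)[nH]c1=O`, has not yet been tested in this assay. It differs from compound 2 by methyl in place of hydrogen on a saturated chain carbon, four bonds along the chain from an aromatic carbon, the same kind of change as from compound 1 to compound 3, though the place is not the same: there the carbon is bound to an aromatic carbon and a saturated chain carbon, here it is four bonds along the chain from an aromatic carbon. Going by the values given here, since every value so far is a limit, the step is expected to be a number no higher from compound 2 to compound 4 (the limit leaves the size open), and compound 4 is expected to give about 500 ug/mL, between 200 ug/mL and 1200 ug/mL.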

Compound 4, concentration for 50% inhibition: 328 ug/mL
Estimate against measurement, compound 4: 1.5-fold (0.18 log units) above; measured number inside the range.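

In this assay, as far as these compounds go, methyl in place of hydrogen on a saturated chain carbon, four bonds along the chain from an aromatic carbon, gives an at least 1.5-fold lower number from compound 2 to compound 4 (0.18 log units; that floor lies within the scatter), so this step shows no change beyond the usual scatter, although the true size stays open on the side of a larger step. The step from compound 1 to compound 3 is the same kind of change on another core and at another place, and it cannot be read because both of its ends are limits rather than numbers: the limit of > 500 ug/mL in this assay, at which 3 of the 4 values shown sit. The compounds shown therefore say nothing on whether this change carries from one core to the other, as no pair puts it at the same place on both cores with numbers at both ends.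

From the compounds shown here alone, whether a longer chain on the core of compound 2 would give a clearly lower number remains open. So does the effect of an amine or a carboxylic acid in place of the chain on either core.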